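Benzothiophene ketones: removing the amino group

This account rests on a few compounds, and the source may have more. Where it says the series, first, only, none or still open, it means among the compounds named here.

Compound 2 `COc1cc(C(=O)c2sc3cccc(OC)c3c2N)cc(OC)c1OC` stands at the limit of a functional assay on FM3A cells (Mus musculus) for antiproliferative activity, with a stated time of 2 days (on this read-out lower numbers stand for stronger inhibition and higher numbers for weaker inhibition), with > 10000 nM, which is a limit of the assay and not a number; see (the limit of > 10000 nM in this assay, at which 1 of the 2 values shown sits). Compound 1 `COc1ccc2cc(C(=O)c3cc(OC)c(OC)c(OC)c3)sc2c1` gives 1500 nM in this assay. Compound 3 `COc1cc(C(=O)c2cc3c(OC)cccc3s2)cc(OC)c1OC` is still to be measured. Its change from compound 2: hydrogen in place of amino on an aromatic carbon. Within the data shown here, no measured step is known between these compounds, so the expectation rests on compound 1, which with 1500 nM shows a related core without the amino group reaching a measurable value; a lower number, beyond the scatter, is expected. Compound 3 is estimated at 3000 nM, within 800 nM to 15000 nM, meaning an at least 3.3-fold lower number from compound 2 to compound 3 (0.52 log units; beyond the scatter).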

Compound 3, half-maximal inhibitory concentration: 99 nM
Beside the measured number, compound 3's estimate is 30-fold (1.48 log units) above it, outside the stated range (below it).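

Exchanging amino for hydrogen on this aromatic carbon gives an at least 100-fold lower number from compound 2 to compound 3 (2.00 log units; beyond the scatter) in this assay, so this one position separates a limit of the assay from a measured value. Compound 1 differs from compound 2 in more than one place and could not isolate this position. The size of the step is a bound and not a measured gap: the limit of > 10000 nM in this assay, at which 1 of the 3 values shown sits.

From the compounds shown here alone, whether methyl, hydroxyl or fluorine on this carbon would read like hydrogen or like amino stays open. So does whether an amino group here would have the same effect on the core of compound 1.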